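Acylguanidine Sulfones: From a Pentyl Chain to a Sulfanyl Group

The source may report more compounds than this note shows. Statements on the series, on what has been measured and on what is new or still open speak of the compounds shown alone.

Measured compounds:
Compound 1 `Cc1c(C(=O)N=C(N)N)cc(S(C)(=O)=O)c(Cl)c1C` gives 58 nM in a functional assay for inhibition of sodium/hydrogen exchanger (Oryctolagus cuniculus); on this read-out higher numbers stand for weaker inhibition and lower numbers for stronger inhibition.
Compound 2 `CCCCCc1cc(C)c(C(=O)N=C(N)N)cc1S(C)(=O)=O` gives 27 nM in this assay.

Compound 2 stands at the lower of the two numbers, so it is the stronger inhibitor of the pair, and its gap to compound 1 lies beyond the usual scatter. Compound 3 `Cc1cc(SC(C)C)c(S(C)(=O)=O)cc1C(=O)N=C(N)N` has not yet been measured. It differs from compound 2 in one place: isopropylsulfanyl in place of pentyl on an aromatic carbon. The group that leaves and the group that enters are of similar size, and neither carries a charge; the entering group brings one hydrogen-bond acceptor. Among the compounds with values here, with only two measured compounds, and no measured pair that shows this particular exchange, no firm direction can be read from the numbers. The step from compound 2 to compound 3 is therefore expected to be small, a 1.3-fold higher number from compound 2 to compound 3 (0.11 log units; within the scatter), within the scatter. Compound 3 is estimated at 35 nM, with a range from 12 nM to 100 nM.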

Compound 3, half-maximal inhibitory concentration: 12 nM
Beside the measured number, compound 3's estimate is 2.9-fold (0.46 log units) above it, within the range that was stated.
By their numbers in this assay, from the lowest: compound 3; then compound 2; then compound 1.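

In this assay, putting isopropylsulfanyl in place of pentyl gives a 2.3-fold lower number from compound 2 to compound 3 (0.35 log units; beyond the scatter) and so, although modest, the change is a real gain in inhibition. Within the data shown here, this is the first measured change at this aromatic carbon, ortho to the methylsulfonyl group, and it shows that a straight pentyl chain is not needed there for inhibition at this level, since a branched group joined through sulfur does better. No measurement shown explains the gain, so it cannot be assigned to the sulfur, the branching or anything else.

A single pair leaves the roles of the sulfur and the branching unseparated, and a plain isopropyl, an isopropoxy or a propylsulfanyl group on the same carbon would pull them apart. From the compounds shown here alone, how this position responds to an amine or a phenylsulfanyl group also remains open.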